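The source may report more compounds than this note shows. Statements on the series, on what has been measured and on what is new or still open speak of the compounds shown alone.

In a functional assay on HCT-116 cells (Homo sapiens) for antiproliferative activity, read by sulforhodamine B assay, with a stated time of 72 h (a lower number here means a stronger inhibitor, a higher number a weaker inhibitor), compound 1 `Cn1ncc(Cl)c1-c1cc(C(=O)N[C@@H]2CN[C@H](CCNS(C)(=O)=O)C[C@H]2c2ccc(F)c(F)c2)oc1Cl` gives 920 nM, compound 2 `Cn1ncc(Cl)c1-c1cc(C(=O)N[C@@H]2CN[C@H](CC(O)CO)C[C@H]2c2ccc(F)c(F)c2)oc1Cl` gives 800 nM and compound 3 `Cn1ncc(Cl)c1-c1cc(C(=O)N[C@@H]2CN[C@H](CC(O)CO)C[C@H]2c2ccc(Cl)c(Cl)c2)oc1Cl` gives 1110 nM. Compound 3 therefore lies within the scatter of both other compounds. Compound 4 `Cn1ncc(Cl)c1-c1cc(C(=O)N[C@@H]2CN[C@H](CCCO)C[C@H]2c2ccc(Cl)c(Cl)c2)oc1Cl` has hydrogen in place of hydroxy on a saturated chain carbon bound to two saturated chain carbons, so 2,3-dihydroxypropyl becomes 3-hydroxypropyl. Going by the values given here, no measured step makes this exact change. The closest evidence is the side-chain exchange a 1.2-fold lower number from compound 1 to compound 2 (0.06 log units; within the scatter), alongside the aryl exchange a 1.4-fold higher number from compound 2 to compound 3 (0.14 log units; within the scatter). Both are small, so no step beyond the scatter is expected in this assay. The expected step is a 1.2-fold lower number from compound 3 to compound 4 (0.07 log units; within the scatter). Compound 4 is estimated at 950 nM, with an expected range of 430 nM to 2100 nM.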

Compound 4, half-maximal inhibitory concentration: 510 nM
For compound 4 the middle estimate is 1.9-fold (0.27 log units) above the measured one; the range from low to high includes it.
By their numbers in this assay, from the lowest: compounds 4, 2, 1 and 3 (each within the scatter of the next, the first and the last beyond it).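

In this assay, hydrogen in place of hydroxy on a saturated chain carbon bound to two saturated chain carbons gives a 2.2-fold lower number from compound 3 to compound 4 (0.34 log units; beyond the scatter) and is the only step shown that lies beyond the scatter, whereas the earlier side-chain exchange, a 1.2-fold lower number from compound 1 to compound 2 (0.06 log units; within the scatter), stays within it. The side chain can therefore move the number modestly when 2,3-dihydroxypropyl becomes 3-hydroxypropyl on the 3,4-dichlorophenyl compounds. No measurement shown here accounts for this step.

From the compounds shown here alone, whether the same change holds with 3,4-difluorophenyl remains open, as does the effect of an amine, a carboxylic acid or a longer chain at this position.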